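Cytotoxicity of two amide analogues on hamster kidney cells

The source may report more compounds than this note shows. Statements on the series, on what has been measured and on what is new or still open speak of the compounds shown alone.

Compound 1 `CC(CSc1nnc(-c2ccncc2)s1)C(=O)Nc1c(Cl)cccc1Cl`: > 50000 nM
Compound 2 `CC(CSc1nnc(-c2ccncc2)s1)C(=O)NCc1ccc(Cl)cc1`: "not determined" (no result reported)

In an ADME assay on BHK-21 cells (Mesocricetus auratus) for cytotoxicity, with a stated time of 3 days (a higher number here means that more compound is tolerated, a lower number that less compound is tolerated), compound 1 gives > 50000 nM, which is a limit of the assay rather than a number. In this assay compound 2 gives "not determined" (no result reported). Its only reference is the shared core's limit, (the limit of > 50000 nM in this assay, at which 1 of the 2 values shown sits). Compound 3 `CC(CSc1nnc(-c2ccncc2)s1)C(=O)Nc1ccccc1` differs from compound 2 by phenyl in place of 4-chlorobenzyl on an amide-type nitrogen. Among the compounds with values here, with no measured step between compounds, no change beyond the scatter in this assay is expected. Compound 3 is therefore estimated at 60000 nM, within a range from 20000 nM to 150000 nM.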

Compound 3, half-maximal cytotoxic concentration: > 50000 nM
Compound 3: only a limit was reported; the forecaster's own chance of this, stated with the estimate: 70%; the middle value is on the limit's open side.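

Compound 1 and compound 3 both report only a limit of the assay, so no step between them can be read: the limit of > 50000 nM in this assay, at which 2 of the 3 values shown sit.

As far as these compounds go, what stays open is the concentration at which either compound becomes toxic in this assay.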